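Carboxylic acid replaces pyridine on the aryl tetrazole ketone

This account rests on a few compounds, and the source may have more. Where it says the series, first, only, none or still open, it means among the compounds named here.

Measured so far:
Compound 1, `CCCCCCCCc1ccc(OCC(=O)Cn2nnnc2-c2cccc(Cl)c2)cc1`: 360 nM
Compound 2, `CCCCCCCCc1ccc(OCC(=O)Cn2nnnc2-c2cccnc2)cc1`: 190 nM

In an assay on microsomes from brain for inhibition of Fatty-acid amide hydrolase 1 (Rattus norvegicus), read by fluorescence and HPLC, with a stated time of 60 min (on this read-out higher numbers stand for weaker inhibition and lower numbers for stronger inhibition), compound 2 gives 190 nM, the lowest of the two numbers; its nearest neighbour is compound 1, and the step of a 1.9-fold lower number from compound 1 to compound 2 (0.28 log units; within the scatter) lies within the scatter. Compound 3, `CCCCCCCCc1ccc(OCC(=O)Cn2nnnc2-c2cccc(C(=O)O)c2)cc1`, has not yet been tested. The change from compound 2 is 3-carboxyphenyl in place of pyridin-3-yl on an aromatic carbon. For the measured compounds named here, only one measured step touches this position, the exchange of 3-chlorophenyl for pyridin-3-yl, and it stayed within the scatter, so this position has so far tolerated a change of aromatic group without a clear shift. Going by the values given here, no measured compound carries a carboxylic acid, so the data give no direct guide to this group. Compound 3 is therefore expected to land near compound 2, with a step of a 1.6-fold higher number from compound 2 to compound 3 (0.20 log units; within the scatter) that is not expected to exceed the scatter. The estimate for compound 3 in this assay is 300 nM, with a range from 80 nM to 1200 nM.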

Compound 3, half-maximal inhibitory concentration: 1800 nM
Beside the measured number, compound 3's estimate is 6.0-fold (0.78 log units) below it, outside the stated range (above it).
By their numbers in this assay, from the lowest: compounds 2 and 1 (each within the scatter of the next); then compound 3.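

In this assay, for the compounds shown here, this position proves less forgiving than the earlier compounds suggested: 3-carboxyphenyl gives a 9.5-fold higher number from compound 2 to compound 3 (0.98 log units; beyond the scatter) and a 5.0-fold higher number from compound 1 to compound 3 (0.70 log units; beyond the scatter), whereas the exchange of 3-chlorophenyl for pyridin-3-yl had stayed within the scatter. The second of these steps keeps the phenyl ring and swaps only chloro for carboxy, so among these three compounds the weaker inhibition goes with the carboxy group and not with a simple change of aromatic group. Nothing available explains this shift in the number.

The compounds shown leave open whether a methyl ester or a primary amide in place of the carboxy group would give a number like that of compound 3 or return towards that of compound 2. As far as these compounds go, how an aminomethyl group on the same phenyl ring would behave also remains open.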